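The source may hold more compounds than are shown below. What is called first, only, known or untested is meant among the compounds shown, and "the series" means these compounds.

Among the measured compounds shown here, compound 2 `Cc1cc(NCc2nccn2C)n2nc(C)c(-c3ccccc3)c2n1` gives, in a physicochemical assay for solubility, read by HPLC, using the shake flask method, measured as kinetic solubility, with a stated time of 2 h, at pH 7.4 (a higher number here means a more soluble compound, a lower number a less soluble compound), 26900 nM, the higher of the two numbers available; the only other measured compound, compound 1 `Cc1cc(NCCCc2ccccn2)n2nc(C)c(-c3ccccc3)c2n1`, gives in this assay 5900 nM. For the measured compounds named here, the single measured step, a 4.6-fold higher number from compound 1 to compound 2 (0.66 log units; beyond the scatter), therefore places compound 2 at the top of this small pair.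

Compound 3 `Cc1cc(NCc2ccco2)n2nc(C)c(-c3ccccc3)c2n1` is not yet measured. It differs from compound 2 in one place: furan-2-yl in place of 1-methyl-1H-imidazol-2-yl on a saturated chain carbon bound to a nitrogen on an aromatic ring. Going by the values given here, no measured step covers this exact exchange; the step from compound 1 to compound 2 concerns a different pair of groups and bears on it only loosely, as a sign that the group in this position can move the number by a modest amount. With one acceptor fewer on the entering group than on the leaving one, a modest decrease is expected for compound 3, estimated as a 3.0-fold lower number from compound 2 to compound 3 (0.48 log units; beyond the scatter), giving 9000 nM with a range from 3000 nM to 27000 nM.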

Compound 3, solubility: < 5000 nM
Compound 3: a limit, no number; the forecaster's own chance of this, stated with the estimate: 5%; at least 1.8-fold (0.25 log units) between middle value and limit.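

In this assay compound 3 gives a limit and not a number: the limit of < 5000 nM in this assay, at which 1 of the 3 values shown sits. Even so, the exchange of 1-methyl-1H-imidazol-2-yl for furan-2-yl on a saturated chain carbon bound to a nitrogen on an aromatic ring has a readable size, an at least 5.3-fold lower number from compound 2 to compound 3 (0.73 log units; beyond the scatter), so swapping one five-membered aromatic ring for another in this place moves the number, which the earlier pair, with its 2-(pyridin-2-yl)ethyl group, did not show. The other step, an at least 1.1-fold lower number from compound 1 to compound 3 (0.07 log units; that floor lies within the scatter), fixes no order between the two.

Going by these compounds, how far the true number of compound 3 lies past its limit stays open. Also open, on these data alone, is whether an amine such as morpholin-4-yl or a carboxylic acid in this place would give a number nearer that of compound 2 or of compound 3.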